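A few compounds are considered here, and "the series" means these few. Any claim that something is new, unique, unknown or untested is made for them only; others in the source may bear on it.

Working notes on the series, pleural-cavity inhibition in the rat.

Two compounds of the set carry numbers in a functional assay on the whole organism (Pleural cavity) for inhibition, with Rattus norvegicus as the target, at a dose of 25 mg/kg; on this read-out higher numbers stand for more inhibition at the one dose given (going by the name of the read-out) and lower numbers for less inhibition. Compound 1, `CC1(Cc2ccccc2)C(=O)N(c2ccccc2)c2ncccc21`, gives 9% in this assay. Compound 2, `CC1(C)C(=O)N(c2ccccc2)c2ncc(Br)cc21`, gives 29% in this assay. Going by the values given here, compound 1 therefore stands lowest of the two; its only neighbour, compound 2, lies higher by a gap that is beyond the usual scatter of this read-out. Among the compounds with values here, compound 2 differs from compound 1 in more than one place, so no single step between them can be read, and the pair shows only that one member sits low and the other clearly higher.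

The next compound, compound 3, `CC1C(=O)N(c2ccccc2)c2ncccc21`, has not yet been measured in this assay. Against compound 1 the change is hydrogen in place of benzyl on a saturated ring carbon. Within the data shown here, no measured pair in the set differs by this kind of change, so the expectation rests on the low position of compound 1 alone. The step expected is a number 6 percentage points higher from compound 1 to compound 3 (within the scatter), a small movement, not clearly beyond the scatter, with only a slight lean upward. Compound 3 is estimated at 15%, within a range from 0% to 35%.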

Compound 3, a percentage reported as inhibition, in the whole organism at one dose (the size of the read-out at that dose, not a potency): 29%
Compound 3: the middle estimate sits 14 percentage points below what was measured; the range from low to high includes it.
By their numbers in this assay, from the lowest: compound 1; then compounds 2 and 3 (each within the scatter of the next).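

In this assay the series gives its first readable step, a number 20 percentage points higher from compound 1 to compound 3 (beyond the scatter), and it shows that this saturated ring carbon responds to the change: with hydrogen in place of benzyl, the inhibition at the one dose does not fall but rises. The benzyl group, with its six-membered aromatic ring of carbon only, is therefore not required at this position for the effect seen here, at least in this single pair on the core of compound 1. No evidence bearing on the step is at hand, and it stands as an observation without an explanation.

The compounds shown leave open whether a group of intermediate kind on this ring carbon, such as an ethyl group, a longer alkyl chain, an aminomethyl group or a carboxylic acid on a short chain, would give a number nearer to compound 1 or to compound 3. They also leave open what a bromine atom alone contributes, as compound 2 differs from compound 3 in more than one place and no single step can be read between them.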